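This account rests on a few compounds, and the source may have more. Where it says the series, first, only, none or still open, it means among the compounds named here.

Compounds measured so far:
Compound 1, `Cc1ccc2[nH]c(C(=O)N[C@H]3CCN(S(=O)(=O)c4cccnc4)C[C@@H]3C(=O)NCCN(C)C)cc2c1`; in a functional assay on HEK293 cells for agonist activity at growth hormone secretagogue receptor type 1 (Homo sapiens), read by HTRF and inositol phosphate accumulation, with a stated time of 90 min, in the presence of a further agent that is not named here (a higher number here means a larger maximal response, a lower number a smaller maximal response), compound 1 gives 93%.
Compound 2, `Cc1ccc2[nH]c(C(=O)N[C@H]3CCN(S(=O)(=O)C4CC4)C[C@@H]3C(=O)NCCN(C)C)cc2c1`; in this assay compound 2 gives 95%.
Compound 3, `Cc1ccc2[nH]c(C(=O)N[C@H]3CCN(S(=O)(=O)N4CCCCC4)C[C@@H]3C(=O)NCCN(C)C)cc2c1`; in this assay compound 3 gives 105%.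

All three share one core and differ only in the group on the sulfonyl sulfur. Compound 3 stands apart from compound 1 by a number 12 percentage points higher from compound 1 to compound 3 (beyond the scatter), which is beyond the scatter though modest. Against compound 2 the difference a number 10 percentage points higher from compound 2 to compound 3 (within the scatter) is within the scatter, so compounds 2 and 3 cannot be told apart, and a number 2 percentage points higher from compound 1 to compound 2 (within the scatter) is likewise within the scatter.

Compound 4, `Cc1ccc2[nH]c(C(=O)N[C@H]3CCN(S(=O)(=O)N4CCOCC4)C[C@@H]3C(=O)NCCN(C)C)cc2c1`, continues this series at the same position: morpholin-4-yl in place of piperidin-1-yl on a sulfonyl sulfur. For the measured compounds named here, no measured step swaps these two particular groups, but every measured step changes the group on the sulfonyl sulfur, and none of them moved the maximal response by more than a modest amount. The bearing of those steps is therefore that this exchange is expected to give no shift beyond the scatter, in either direction.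

Compound 4 is thus estimated at 100%, with a range from 86% to 112%, which means an expected step of a number 5 percentage points lower from compound 3 to compound 4 (within the scatter).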

Compound 4, largest response reached (Emax), in percent of the reference or control that the assay uses in the growth hormone secretagogue receptor type 1 assay: 98%
The estimate for compound 4 lay 2 percentage points above the measured number; the measured number falls inside the stated range.
By their numbers in the growth hormone secretagogue receptor type 1 assay, from the lowest: compounds 1, 2, 4 and 3 (each within the scatter of the next, the first and the last beyond it).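

In the growth hormone secretagogue receptor type 1 assay, morpholin-4-yl on the sulfonyl sulfur gives a response that cannot be told apart from those of the other three groups: a number 7 percentage points lower from compound 3 to compound 4 (within the scatter), a number 3 percentage points higher from compound 2 to compound 4 (within the scatter) and a number 5 percentage points higher from compound 1 to compound 4 (within the scatter). The second read-out adds a new dimension, since in a physicochemical assay for lipophilicity, measured as octanol-water partition, at pH 7.4 (a lower number here means a more polar compound, a higher number a more lipophilic compound), compound 3 gives 2.3 and compound 4 gives 1. Exchanging piperidin-1-yl for morpholin-4-yl, a ring of the same size that has one hydrogen-bond acceptor where piperidin-1-yl has none, thus makes the compound clearly more polar while the maximal response stays within the scatter, so this position can change polarity substantially with no visible cost in that response: the measured distribution coefficient of compound 3, 2.3, and of compound 4, 1, a number 1.30 log units lower (beyond the scatter)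

As far as these compounds go, whether the response would also hold with a piperazin-1-yl group, whose second ring nitrogen carries a free amine hydrogen, or with a carboxylic acid at the end of a short chain on the sulfonyl sulfur remains open. From the compounds shown here alone, a maximal response also says nothing about the concentration needed to reach it, so what this exchange does to that concentration remains open too.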